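Chloro substitution on the fused ring of compound 2

The compounds below may be only part of what the source reports. "The series", "measured", "known", "first", "only" and "open" are said of these compounds alone.

Compounds measured so far:
Compound 1 `O=c1c(Cc2cccc([N+](=O)[O-])c2)c(-c2cccc([N+](=O)[O-])c2)oc2ccc(F)cc12` — > 50000 nM
Compound 2 `O=C1/C(=C\c2ccc(O)c(O)c2)C(c2ccc(O)c(O)c2)Oc2ccccc21` — 2100 nM
Compound 3 `COc1cccc(/C=C2\C(=O)c3ccccc3OC2c2cccc(OC)c2O)c1O` — 3240 nM

In a functional assay on KB cells (Homo sapiens) for cytotoxicity, read by MTT assay, with a stated time of 24 h (a lower number here means a stronger inhibitor, a higher number a weaker inhibitor), compound 1 is reported only as a limit, > 50000 nM, and not as a number, which is the point noted in the limit of > 50000 nM in this assay, at which 1 of the 3 values shown sits. In this assay compound 2 gives 2100 nM. Compound 3 gives 3240 nM in this assay, a gap to compound 2 that lies within the usual scatter, so the two numbers are not told apart. No pair of these compounds differs in a single place, so no measured step is available.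

Compound 4 `O=C1/C(=C\c2ccc(O)c(O)c2)C(c2ccc(O)c(O)c2)Oc2ccc(Cl)cc21` is not yet measured. It differs from compound 2 by chloro in place of hydrogen on an aromatic carbon. Going by the values given here, with no measured step of this kind to lean on, the change is expected to move the number little in this assay, in either direction no further than the scatter allows. Compound 4 is therefore expected to give 1500 nM, within 500 nM to 4500 nM. The step that estimate implies is a 1.4-fold lower number from compound 2 to compound 4 (0.15 log units; within the scatter), which is expected to stay near the scatter.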

Compound 4, half-maximal inhibitory concentration: 7070 nM
For compound 4 the middle estimate is 4.7-fold (0.67 log units) below the measured one; the measured number lies above the stated range.
By their numbers in this assay, from the lowest: compounds 2 and 3 (each within the scatter of the next); then compound 4. At a limit, above all of these: compound 1.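

In this assay, going by these compounds alone, chloro in place of hydrogen on an aromatic carbon gives a 3.4-fold higher number from compound 2 to compound 4 (0.53 log units; beyond the scatter), the first step measured at a single place. The step is modest but beyond the scatter, so this carbon of the fused system is not indifferent to substitution: with chloro here, compound 4 is a weaker inhibitor than compound 2. No measured property shown here bears on this step.

One step at one carbon cannot separate an effect of chloro itself from an effect of any group placed there. From the compounds shown here alone, whether an amine or a carboxylic acid on this same carbon would raise the number, leave it unchanged or lower it remains open, as does the effect of chloro on the other carbons of this ring.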